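The source may hold more compounds than are shown below. What is called first, only, known or untested is meant among the compounds shown, and "the series" means these compounds.

Measured so far in a physicochemical assay for solubility, measured as kinetic solubility, at pH 7.4; a lower number here means a less soluble compound, a higher number a more soluble compound:
- compound 1 `COc1cc(N2CCN(C(=O)C3CCC(O)CC3)CC2)ccc1Nc1nc(NC2CCCCC2)c2nc[nH]c2n1` gives 19000 nM
- compound 2 `COc1cc(N2CCN(C(=O)N3CCN(C)CC3)CC2)ccc1Nc1nc(NC2CCCCC2)c2nc[nH]c2n1` gives 75000 nM
- compound 3 `COc1cc(N2CCC(C(=O)N3CCC(N(C)C)C3)CC2)ccc1Nc1nc(NC2CCCCC2)c2nc[nH]c2n1` gives 38000 nM

Compound 3 lies within the usual scatter of both compound 1 and compound 2, although those two are separated by a modest step beyond the scatter (a 3.9-fold higher number from compound 1 to compound 2 (0.60 log units; beyond the scatter)). Compound 4 `COc1cc(N2CCC(C(=O)N3CC(O)C3)CC2)ccc1Nc1nc(NC2CCCCC2)c2nc[nH]c2n1` has 3-hydroxyazetidin-1-yl in place of 3-(dimethylamino)pyrrolidin-1-yl on a carbonyl carbon. For the measured compounds named here, no measured step covers this exact exchange. The closest is the step from compound 1 to compound 2, where 4-methylpiperazin-1-yl replaced 4-hydroxycyclohexyl on a carbonyl carbon. The new change runs the opposite way, with a hydroxy-bearing group entering and an amine-bearing group leaving. That single step comes from a different pair of compounds, so it offers only rough guidance. The expected step is small (a 1.9-fold lower number from compound 3 to compound 4 (0.28 log units; within the scatter)). Compound 4 is estimated at 20000 nM (expected range 8000 nM to 50000 nM).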

Compound 4, solubility: 19000 nM
The estimate for compound 4 lay 1.1-fold (0.02 log units) above the measured number; the measured number falls inside the stated range.
By their numbers in this assay, from the lowest: compounds 1, 4, 3 and 2 (each within the scatter of the next, the first and the last beyond it).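

In this assay, on a carbonyl carbon whose other neighbour is a saturated ring carbon, 3-hydroxyazetidin-1-yl in place of 3-(dimethylamino)pyrrolidin-1-yl gives a 2.0-fold lower number from compound 3 to compound 4 (0.30 log units; within the scatter) at this position. For the compounds shown here, the exchange thus changes the ring and removes the dimethylamino group, yet the result stays inside the scatter, whereas the only earlier step, a 3.9-fold higher number from compound 1 to compound 2 (0.60 log units; beyond the scatter), lay beyond it and involved different groups on a different neighbouring atom. No evidence accompanies this result that could explain it.

The compounds shown do not separate ring size from the substituent, and a pair such as 3-hydroxypyrrolidin-1-yl and 3-(dimethylamino)azetidin-1-yl would be needed for that. Also open, as far as these compounds go, is how a carboxylic acid on the same ring would read at this carbonyl carbon.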